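Aryl sulfonyl in place of benzyl on the ring nitrogen

The source may report more compounds than this note shows. Statements on the series, on what has been measured and on what is new or still open speak of the compounds shown alone.

Compound 1 `COc1ccc(-c2cc(=O)c3c(OC)cc(OC)cc3n2Cc2ccccc2)cc1` was examined in a functional assay on HepG2 cells (Homo sapiens) for antiproliferative activity, with a stated time of 72 h (on this read-out lower numbers stand for an effect already at smaller amounts and higher numbers for an effect only at larger amounts of compound), and in this assay compound 1 gives only a limit, > 17300 nM. Compound 2 `COc1ccc(-c2c(I)c(=O)c3c(OC)cc(OC)cc3n2S(=O)(=O)c2ccc(OC)cc2)cc1` likewise reaches only a limit in this assay, > 17300 nM. Both values sit at the same limit, (the limit of > 17300 nM in this assay, at which 2 of the 2 values shown sit), so compound 1 cannot be separated from compound 2 and neither gives a number.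

Compound 3 `COc1ccc(-c2cc(=O)c3c(OC)cc(OC)cc3n2S(=O)(=O)c2ccc(Cl)cc2)cc1` awaits measurement. It differs from compound 1 by (4-chlorophenyl)sulfonyl in place of benzyl on an aromatic nitrogen. Compound 2 already carries an aryl sulfonyl group on that same nitrogen and yields only a limit. Going by the values given here, for the unmeasured compound, the expected step is a step that the limit leaves unreadable from compound 1 to compound 3, that is, no change beyond the scatter, since no measured pair here points toward a gain. Compound 3 is therefore estimated at about 20000 nM in this assay, within 8000 nM to 60000 nM, and most likely reported once more as a limit.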

Compound 3, half-maximal effective concentration: > 34400 nM
Compound 3 ended at the assay's limit; the forecaster's own chance of this, stated with the estimate: 75%; middle value at least 1.7-fold (0.23 log units) from the limit.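

Going by these compounds alone, compound 1 and compound 3 both give only limits in this assay, so no step between them can be read. The compounds shown leave open whether any group on that aromatic nitrogen would give a readable value in this assay.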